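Chloro Position in a Thiophene Series at the Adenosine A3 Receptor

A few compounds are considered here, and "the series" means these few. Any claim that something is new, unique, unknown or untested is made for them only; others in the source may bear on it.

Three members of a small set of aminothiophene ketones have been tested in an assay on CHO cells for displacement of a labelled ligand from adenosine receptor A3 (Homo sapiens), read by scintillation counting, tested at 10 uM; a higher number here means more inhibition at the concentration tested (going by the name of the read-out), a lower number less inhibition. Compound 1 `CC(C)(C)Cc1c(-c2ccccc2)sc(N)c1C(=O)c1ccc(Cl)cc1` gives 1% in this assay. Compound 2 `CC(C)(C)Cc1c(-c2ccccc2)sc(N)c1C(=O)c1cccc(Cl)c1` gives 5%. Compound 3 `COc1ccc(-c2sc(N)c(C(=O)c3ccc(Cl)cc3)c2CC(C)(C)C)cc1` gives 2%. All three sit close together, and neither of the two recorded steps leaves the range of ordinary repeat scatter: the change from compound 1 to compound 2, (3-chlorophenyl in place of 4-chlorophenyl on a carbonyl carbon), produced a number 4 percentage points higher from compound 1 to compound 2 (within the scatter), and the change from compound 1 to compound 3, (methoxy in place of hydrogen on an aromatic carbon), produced a number 1 percentage points higher from compound 1 to compound 3 (within the scatter).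

Compound 4 `COc1ccc(-c2sc(N)c(C(=O)c3cccc(Cl)c3)c2CC(C)(C)C)cc1` has not yet been measured. It differs from compound 3 by 3-chlorophenyl in place of 4-chlorophenyl on a carbonyl carbon, the same change that links compound 1 to compound 2, made here on the core of compound 3, which differs from the core of compound 1 by the methoxy group already described. Since that change, when made from compound 1 to compound 2, gave only a number 4 percentage points higher from compound 1 to compound 2 (within the scatter), compound 4 is expected to move from compound 3 by about a number 3 percentage points higher from compound 3 to compound 4 (within the scatter) in this assay. On that basis the estimate for compound 4 in this assay is 5%, with a plausible range from 0% to 13%, because compound 3 itself gave only 2% and nothing in the set points to a larger effect.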

Compound 4, a percentage reported as inhibition, at one concentration (the size of the read-out at that concentration, not a potency): 2%
Compound 4: the middle estimate sits 3 percentage points above what was measured, within the range that was stated.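

In this assay, 3-chlorophenyl in place of 4-chlorophenyl on the carbonyl carbon gave no change at the digits printed from compound 3 to compound 4 (within the scatter), and set beside the same change on the core of compound 1, this step does not stand apart: the same change on two cores in this assay, a number 4 percentage points higher (within the scatter) from compound 1 to compound 2 and no change at the digits printed (within the scatter) from compound 3 to compound 4, 4 percentage points apart, within the scatter of two such steps. The methoxy group, read across the pair carrying 3-chlorophenyl, gave a number 3 percentage points lower from compound 2 to compound 4 (within the scatter), and it likewise agrees with its earlier step on the other core: the same change on two cores in this assay, a number 1 percentage points higher (within the scatter) from compound 1 to compound 3 and a number 3 percentage points lower (within the scatter) from compound 2 to compound 4, 4 percentage points apart, within the scatter of two such steps. For the compounds shown here, this shows that, for these four compounds, the chlorine shift reads the same on both cores within ordinary repeat scatter, but it does not show that the shift has any effect of its own, and since no step here leaves the scatter, it says nothing about whether a real effect would carry from one core to the other.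

As far as these compounds go, what remains open is whether a different group in place of the chlorine, such as a methyl, a nitrile or a trifluoromethyl, would give a number clear of the scatter in this assay. The same question stands for a longer chain or an amine on the shared core, where a step large enough to test transfer between cores might or might not appear.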